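The source may report more compounds than this note shows. Statements on the series, on what has been measured and on what is new or still open speak of the compounds shown alone.

Of the compounds shown here, three have been measured in an assay for inhibition of glucose-6-phosphatase catalytic subunit 1 (Rattus norvegicus), tested at 100 uM; on this read-out lower numbers stand for less inhibition and higher numbers for more inhibition at the one concentration tested (going by the name of the read-out). Compound 1 `O=C(/C=C/c1ccc(Cl)cc1)C[C@@H]1O[C@H](CO)[C@@H](O)[C@H](O)[C@H]1O` gives -25.3%, the lowest of the three numbers. Compound 2 `CCOC(=O)C(C(=O)OCC)C(CC(=O)C[C@@H]1O[C@H](CO)[C@@H](O)[C@H](O)[C@H]1O)c1ccc2ccccc2c1` gives 4.6%, and compound 3 `CCOC(=O)C(C(=O)OCC)C(CC(=O)C[C@@H]1O[C@H](CO)[C@@H](O)[C@H](O)[C@H]1O)c1ccc(OC)c(OC)c1` gives 36.2%. The gap from compound 1 to compound 2 and the larger gap from compound 1 to compound 3 both lie beyond the scatter, so compound 1 stands clearly at the bottom.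

Compound 4 `O=C(/C=C/c1cccnc1)C[C@@H]1O[C@H](CO)[C@@H](O)[C@H](O)[C@H]1O` is not yet measured. It differs from compound 1 in one place: pyridin-3-yl in place of 4-chlorophenyl on a double-bonded chain carbon bound to a double-bonded chain carbon.

Going by the values given here, only one step between measured compounds is known, and it concerns a different kind of change on a different part of the molecule: a number 31.6 percentage points higher from compound 2 to compound 3 (beyond the scatter). That step shows that swapping one aromatic group for another can move this read-out by a large amount, but it says nothing direct about replacing a chlorinated ring with a nitrogen-containing ring on the double-bonded chain carbon. With so little to rest on, the expected step of a number 20.3 percentage points higher from compound 1 to compound 4 (beyond the scatter) points modestly upward, mainly because compound 1 sits at -25.3%, well below the other two.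

For compound 4 the estimated value is -5%, with a range from -30% to 20%.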

Compound 4, a percentage reported as inhibition, at one concentration (the size of the read-out at that concentration, not a potency): -8.1%
Beside the measured number, compound 4's estimate is 3.1 percentage points above it; the range from low to high includes it.
By their numbers in this assay, from the lowest: compound 1; then compound 4; then compound 2; then compound 3.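

In this assay, pyridin-3-yl in place of 4-chlorophenyl on a double-bonded chain carbon bound to a double-bonded chain carbon gives a number 17.2 percentage points higher from compound 1 to compound 4 (beyond the scatter), a modest step that still lies beyond the scatter. Going by these compounds alone, this is the first direct reading at this position, as the only earlier step concerned aromatic groups on a saturated chain carbon, and it shows that the aromatic group on the double-bonded chain carbon also affects the read-out. Even so, compound 4 remains negative at -8.1%, and nothing available explains why the number moves with this change.

The change removes the chlorine and brings in a ring nitrogen at the same time, so these compounds cannot show which of the two matters, or whether both do. An unsubstituted phenyl ring would separate the two parts of the change, while a ring carrying a methoxy group, an amine or a carboxylic acid at this position would show whether the read-out can rise further on this shorter type of chain.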